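The source may hold more compounds than are shown below. What is called first, only, known or untested is meant among the compounds shown, and "the series" means these compounds.

Measured compounds:
Compound 1, `O=c1nc(NCc2ccc(F)cc2)oc2c([N+](=O)[O-])cc(C(F)(F)F)cc12`, in an ADME assay on Vero cells (Chlorocebus sabaeus) for cytotoxicity, read by MTT assay, with a stated time of 48 h; on this read-out lower numbers stand for stronger inhibition and higher numbers for weaker inhibition: > 64 ug/mL, which is a limit of the assay and not a number.
Compound 2, `CN(Cc1ccc2c(c1)OCCO2)c1cc(=O)c2cc(C(F)(F)F)cc([N+](=O)[O-])c2o1`, in this assay: 29.4 ug/mL.

Compound 1 thus stands at the limit of > 64 ug/mL in this assay, at which 1 of the 2 values shown sits, so its own exact value is not known, only that it lies at that limit. Compound 3, `COc1ccc(CNc2nc(=O)c3cc(C(F)(F)F)cc([N+](=O)[O-])c3o2)cc1OC`, has not yet been measured in this assay. The change from compound 1 to compound 3 is 3,4-dimethoxyphenyl in place of 4-fluorophenyl on a saturated chain carbon bound to a nitrogen on an aromatic ring. For the measured compounds named here, no measured pair of compounds shows what this change does, so there is no measured step to lean on. In this assay the expected step is a step that the limit leaves unreadable from compound 1 to compound 3, that is, none beyond the usual scatter, and the result is expected most likely to sit at the limit again. Compound 3 is expected to give 80 ug/mL, within the range 30 ug/mL to 200 ug/mL.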

Compound 3, half-maximal inhibitory concentration: 29.2 ug/mL
Beside the measured number, compound 3's estimate is 2.7-fold (0.44 log units) above it; the whole stated range lies above it.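

In this assay, 3,4-dimethoxyphenyl in place of 4-fluorophenyl on a saturated chain carbon bound to a nitrogen on an aromatic ring gives an at least 2.1-fold lower number from compound 1 to compound 3 (0.34 log units; beyond the scatter). For the compounds shown here, this is the first measured sign that the group at this position can shift the result on the shared core, with the lower number standing for stronger inhibition of the cells. Compound 1 stands at a limit and not at a number, so the full size of this step stays unknown: the limit of > 64 ug/mL in this assay, at which 1 of the 3 values shown sits.

In this change the fluorine leaves and the methoxy groups enter together, so the compounds shown cannot say which of the two matters. From the compounds shown here alone, a plain phenyl, a phenyl with a single methoxy group or a pyridine ring at this position would help separate those parts, and how any of them would read remains open.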